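Swapping the anilide ring on a diazabicyclic nicotinamide scaffold

This account rests on a few compounds, and the source may have more. Where it says the series, first, only, none or still open, it means among the compounds named here.

Of the compounds shown here, three sharing one core have been measured in an assay on cells for displacement of a labelled ligand from Neuronal acetylcholine receptor; alpha3/beta4 (Homo sapiens); a lower number here means a stronger inhibitor, a higher number a weaker inhibitor. Compound 1 `O=C(c1cncc(N2CC3CC(C2)N3)c1)N1CCCc2ccccc21` gives 62 nM, compound 2 `O=C(c1cncc(N2CC3CC(C2)N3)c1)N1CCc2ccccc2C1` gives 21 nM, and compound 3 `O=C(Nc1ccc(F)cc1F)c1cncc(N2CC3CC(C2)N3)c1` gives 50 nM. Among these three numbers, compound 3 holds the second highest; its nearest neighbour is compound 1, whose value lies within the scatter of compound 3, while compound 2 is furthest away, with a lower number that lies beyond the scatter.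

Compound 4 `COc1cccc(NC(=O)c2cncc(N3CC4CC(C3)N4)c2)c1` differs from compound 3 in one place: 3-methoxyphenyl in place of 2,4-difluorophenyl on an amide-type nitrogen. No measured pair in this set isolates such an exchange, so the direction of the step is not anchored by any shown data. The anilide series is represented only by compound 3 itself, and its value sits close to the amide of compound 1, so the expectation for compound 4 is a step of no more than the scatter in either direction, a 1.2-fold higher number from compound 3 to compound 4 (0.08 log units; within the scatter). Compound 4 is therefore estimated at 60 nM, with a range from 20 nM to 180 nM.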

Compound 4, inhibition constant: 265 nM
For compound 4 the middle estimate is 4.4-fold (0.65 log units) below the measured one; the whole stated range lies below it.
By their numbers in this assay, from the lowest: compound 2; then compounds 3 and 1 (each within the scatter of the next); then compound 4.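

In this assay, among the compounds shown here, the exchange of 2,4-difluorophenyl for 3-methoxyphenyl on the amide-type nitrogen gives a 5.3-fold higher number from compound 3 to compound 4 (0.72 log units; beyond the scatter), the first step in this set that isolates a single change. It shows that this position responds to the choice of aryl group, even though both groups have the same number of heavy atoms and each is a six-membered aromatic ring of carbon only. Nothing available here explains why the step goes this way or why it has this size.

The step combines the loss of both fluorines with the arrival of the methoxy group, so the compounds shown do not say which of the two changes carries it. A plain phenyl or a 3-fluorophenyl on the same nitrogen would help to separate these two contributions.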